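The source may hold more compounds than are shown below. What is called first, only, known or untested is meant among the compounds shown, and "the series" means these compounds.

In a functional assay on MCF7 cells (Homo sapiens) for inhibition, read by MTT assay, with a stated time of 48 h (on this read-out lower numbers stand for stronger inhibition and higher numbers for weaker inhibition), compound 1 `COc1ccc(/C=C2\SC(=O)N(CCNC(=O)Nc3c(C)n(C)n(-c4ccccc4)c3=O)C2=O)cc1` gives 5140 nM, while compound 2 `Cc1c(NC(=O)CN2C(=O)S/C(=C\c3ccc([N+](=O)[O-])cc3)C2=O)c(=O)n(-c2ccccc2)n1C` gives 82400 nM. Compound 2 therefore has the higher of the two numbers, and its gap to compound 1 lies beyond the usual scatter of repeat measurements. Compound 2 is the weaker inhibitor of this pair. The two compounds differ in more than one place, so this gap cannot be pinned on any single group.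

Compound 3 `Cc1cc(C)c(/C=C2\SC(=O)N(CC(=O)Nc3c(C)n(C)n(-c4ccccc4)c3=O)C2=O)c(C)c1` departs from compound 2 in one place: 2,4,6-trimethylphenyl stands in place of 4-nitrophenyl on a double-bonded chain carbon bound to a double-bonded ring carbon (2,4,6-trimethylphenyl in place of 4-nitrophenyl on a double-bonded chain carbon bound to a double-bonded ring carbon). Among the measured compounds shown here, no measured pair isolates this swap, so the evidence for its effect is thin. For the measured compounds named here, the only guide is the measured pair, in which compound 1 gives 5140 nM and compound 2 gives 82400 nM, and this leaves more room for the number to fall than to rise. The expected change in this assay is a 2.4-fold lower number from compound 2 to compound 3 (0.37 log units; beyond the scatter), a modest move toward stronger inhibition. For compound 3 the estimated value is 35000 nM, with an expected range of 10000 nM to 100000 nM.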

Compound 3, half-maximal inhibitory concentration: 71100 nM
Estimate against measurement, compound 3: 2.0-fold (0.31 log units) below; the range from low to high includes it.
By their numbers in this assay, from the lowest: compound 1; then compounds 3 and 2 (each within the scatter of the next).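

In this assay, among the compounds shown here, this is the first change made in one place only, on a double-bonded chain carbon bound to a double-bonded ring carbon, and it gives a 1.2-fold lower number from compound 2 to compound 3 (0.06 log units; within the scatter). The swap of 4-nitrophenyl for 2,4,6-trimethylphenyl removes the nitrogen, the oxygens and the hydrogen-bond acceptors of the leaving group, while the six-membered aromatic ring and the number of heavy atoms stay the same, yet the reading does not move beyond the usual scatter of repeat measurements. No supporting measurement is available to explain this result.

For the compounds shown here, this single step covers only two groups at this position, so it cannot show whether the position tolerates every change or whether these two groups merely happen to match. A phenyl ring carrying an amine or a carboxylic acid at this position remains an open test, as does a longer chain linking the ring system to the rest of the molecule, and either could show whether the number can move at all.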